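This account rests on a few compounds, and the source may have more. Where it says the series, first, only, none or still open, it means among the compounds named here.

Measured so far in a functional assay on L1210 cells (Mus musculus) for inhibition; on this read-out higher numbers stand for weaker inhibition and lower numbers for stronger inhibition:
- compound 1 `C=C1[C@H](n2cnc3c(O)nc(N)nc32)O[C@H](CO)[C@H]1O`: 8500 nM
- compound 2 `C=C1[C@H](n2cnc3c(OC)nc(N)nc32)O[C@H](CO)[C@H]1O`: 10000 nM

Going by the values given here, compound 2 cannot be told apart from compound 1, the only other measured member of the series. The step between them is a 1.2-fold higher number from compound 1 to compound 2 (0.07 log units; within the scatter), and it comes from methyl in place of hydrogen on an oxygen on an aromatic ring.

The next change leads to compound 3 `C=C1[C@H](n2cnc3c(S)nc(N)nc32)O[C@H](CO)[C@H]1O`, with sulfanyl in place of methoxy on an aromatic carbon.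

Among the compounds with values here, the single measured step is the only one that bears on this change, and it offers limited guidance. It shows that the methyl on that oxygen made no measurable difference in this assay, but it does not test replacing the oxygen with sulfur. Within the data shown here, no measured compound carries sulfur, so the data give no direct size for this swap. The expectation therefore leans only modestly towards stronger inhibition, with a wide range in both directions.

The expected step is a 2.0-fold lower number from compound 2 to compound 3 (0.30 log units; within the scatter). For compound 3 the estimate is 5000 nM, with an expected range from 800 nM to 15000 nM.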

Compound 3, half-maximal inhibitory concentration: 20000 nM
For compound 3 the middle estimate is 4.0-fold (0.60 log units) below the measured one, and the stated range ends below it.
By their numbers in this assay, from the lowest: compounds 1, 2 and 3 (each within the scatter of the next, the first and the last beyond it).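

In this assay, sulfanyl and methoxy on this aromatic carbon cannot be separated: a 2.0-fold higher number from compound 2 to compound 3 (0.30 log units; within the scatter). Going by these compounds alone, the comparison with the hydroxy group gives the only step that lies beyond the scatter, a 2.4-fold higher number from compound 1 to compound 3 (0.37 log units; beyond the scatter), so sulfanyl reads as modestly weaker than hydroxy at this position, while methoxy cannot be told apart from either. Nothing available explains this small difference between sulfanyl and hydroxy.

With three groups on this carbon, the series spans only a modest range, and the step between its two ends barely clears the scatter, so this position has not yet shown a strong dependence on the group it carries. The compounds shown leave open whether an amine, a chlorine or a methylsulfanyl group on this aromatic carbon would stay within that range or move clearly outside it, and whether a longer chain on the oxygen or sulfur would do the same.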